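A few compounds are considered here, and "the series" means these few. Any claim that something is new, unique, unknown or untested is made for them only; others in the source may bear on it.

In an ADME assay on Vero cells (Chlorocebus sabaeus) for cytotoxicity (on this read-out higher numbers stand for lower toxicity in this test and lower numbers for higher toxicity in this test), compound 1 `COc1ccccc1-c1nn2cnnc2s1` gives only a limit, > 80000 nM. Compound 2 `c1ccc(Oc2ccccc2-c2nn3cnnc3s2)cc1` also gives only a limit, > 50000 nM. Compound 3 `c1cc2c(c(-c3nn4cnnc4s3)c1)OCC2` likewise gives only a limit, > 50000 nM. None of the three therefore has a readable number. Compound 4 `c1ccc(-c2nn3cnnc3s2)c(OCCC2CCOCC2)c1` differs from compound 1 by (oxan-4-yl)methyl in place of hydrogen on a saturated chain carbon bound to an oxygen on an aromatic ring. Among the compounds with values here, the one measured step bearing on this change, a step that the two limits leave unreadable from compound 1 to compound 2, has no readable size and gives no sign of a change in either direction. No shift beyond the usual scatter is therefore expected in this assay, and the estimated step is an at least 1.1-fold lower number from compound 1 to compound 4 (0.05 log units; that floor lies within the scatter). For compound 4 the expected value is 70000 nM, with an estimated range from 30000 nM to 110000 nM.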

Compound 4, half-maximal cytotoxic concentration: > 50000 nM
Compound 4 was reported as a limit; the forecaster's own chance of this, stated with the estimate: 80%; the middle value lies beyond the limit too.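

In this assay compound 1 and compound 4 both stand only as limits and no step can be read between them. The compounds shown leave open where any actual value lies in this assay and whether (oxan-4-yl)methyl in place of hydrogen changes it at all.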